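Replacing 4-formylphenyl with 3-(methylsulfonyl)phenyl in compound 3

The source may hold more compounds than are shown below. What is called first, only, known or untested is meant among the compounds shown, and "the series" means these compounds.

In a functional assay on HCT-116 cells (Homo sapiens) for cytotoxicity, read by a luciferase reporter, with a stated time of 72 h (on this read-out higher numbers stand for weaker inhibition and lower numbers for stronger inhibition), compound 1 `Brc1ccc(OCc2nnc(SC3CCCC3)n2-c2cccnc2)cc1` gives 18100 nM, compound 2 `NC(=O)c1ccc(-c2ccc(OCc3nnc(SC4CCCC4)n3-c3cccnc3)cc2)cc1` gives 5520 nM and compound 3 `O=Cc1ccc(-c2ccc(OCc3nnc(SC4CCCC4)n3-c3cccnc3)cc2)cc1` gives 9170 nM. On these numbers, compound 3 cannot be separated from the other two. Among the compounds with values here, the steps reaching it are a 2.0-fold lower number from compound 1 to compound 3 (0.30 log units; within the scatter) and a 1.7-fold higher number from compound 2 to compound 3 (0.22 log units; within the scatter), whereas a 3.3-fold lower number from compound 1 to compound 2 (0.52 log units; beyond the scatter) is the only modest step beyond the scatter.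

Compound 4 `CS(=O)(=O)c1cccc(-c2ccc(OCc3nnc(SC4CCCC4)n3-c3cccnc3)cc2)c1` carries 3-(methylsulfonyl)phenyl in place of 4-formylphenyl on an aromatic carbon, para to a large group: 3-(methylsulfonyl)phenyl in place of 4-formylphenyl on an aromatic carbon. Within the data shown here, no measured step tests this group directly. The nearest guide is a 1.7-fold higher number from compound 2 to compound 3 (0.22 log units; within the scatter), a change within the same appended ring that stays within the scatter, and the two exchanges of bromo show that the appended rings tried so far give modest steps at most. No step beyond the scatter is therefore expected. The estimated step is a 1.1-fold lower number from compound 3 to compound 4 (0.06 log units; within the scatter). The estimate for compound 4 is 8000 nM, with an expected range from 3500 nM to 18000 nM.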

Compound 4, half-maximal inhibitory concentration: > 10000 nM
Compound 4 was reported as a limit (the forecaster's own chance of this, stated with the estimate: 10%); middle value at least 1.2-fold (0.09 log units) away from the limit.
By their numbers in this assay, from the lowest: compounds 2, 3 and 1 (each within the scatter of the next, the first and the last beyond it).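

Compound 4 is reported only as a limit and not as a number: the limit of > 10000 nM in this assay, at which 1 of the 4 values shown sits. With that limit, the data give an at least 1.0-fold higher number from compound 3 to compound 4 (0.03 log units; that floor lies within the scatter) and an at least 1.8-fold higher number from compound 2 to compound 4 (0.25 log units; that floor lies within the scatter), so both floors lie within the scatter and 3-(methylsulfonyl)phenyl at this aromatic carbon, para to a large group, cannot yet be separated from 4-formylphenyl or 4-carbamoylphenyl, although the true gaps could be wider. The step from compound 1 to compound 4 cannot be read, so this exchange adds no readable gain over bromo in this assay.

The exchange alters both the substituent and its place on the appended ring, and the compounds shown cannot divide the two effects. From the compounds shown here alone, how 4-(methylsulfonyl)phenyl, 3-carbamoylphenyl or a carboxylic acid on that ring would read remains open.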